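The source may report more compounds than this note shows. Statements on the series, on what has been measured and on what is new or still open speak of the compounds shown alone.

Three carbamates built on the same selenocyanate-bearing aniline core were tested in a functional assay on CCRF-CEM cells (Homo sapiens) for cytotoxicity, read by MTT assay, with a stated time of 72 h; on this read-out higher numbers stand for lower toxicity in this test and lower numbers for higher toxicity in this test. Compound 1 `COc1ccc(OC(=O)Nc2ccc([Se]C#N)cc2)cc1` gives 70000 nM in this assay. Compound 2 `CCCOC(=O)Nc1ccc([Se]C#N)cc1` gives 68800 nM in this assay. Compound 3 `O=C(Nc1ccc([Se][Se]c2ccc(NC(=O)OCc3ccccc3)cc2)cc1)OCc1ccccc1`, the diselenide dimer, gives 67900 nM in this assay. Compound 2 stands second highest of the three numbers, but its neighbours on either side lie within the scatter of it: compound 3 sits a hair lower and compound 1 a hair higher, so the three values cannot be ordered.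

Compound 4 `CCCCOC(=O)Nc1ccc([Se]C#N)cc1` has not yet been measured. It differs from compound 2 by methyl in place of hydrogen on a saturated chain carbon, three bonds along the chain from an oxygen next to a carbonyl group, so that the propyl chain of compound 2 becomes a butyl chain. Within the data shown here, no pair of measured compounds shows this particular change. Given that the three measured compounds, which differ far more from one another than compound 4 differs from compound 2, all fall within the scatter of each other, the step from compound 2 to compound 4 in this assay is expected to be small, with no direction beyond the scatter, an expected 1.1-fold lower number from compound 2 to compound 4 (0.02 log units; within the scatter). Compound 4 is therefore estimated to give 65000 nM in this assay, with a range from 30000 nM to 140000 nM.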

Compound 4, concentration lethal to 50% of the cells: 63500 nM
The estimate for compound 4 lay 1.0-fold (0.01 log units) above the measured number; low and high end bracket the measured number.
By their numbers in this assay, from the lowest: compounds 4, 3, 2 and 1 (each within the scatter of the next).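

In this assay, among these compounds, the change from the propyl chain to the butyl chain gives the first direct reading of a single alteration in this set, a step of a 1.1-fold lower number from compound 2 to compound 4 (0.03 log units; within the scatter). The earlier compounds shown here could offer no such reading, since none of them differed from another in one place only; this step now shows that, for this pair, methyl in place of hydrogen on a saturated chain carbon, three bonds along the chain from an oxygen next to a carbonyl group, leaves the number within the scatter. No measurement offered here speaks to the reason for this outcome.

This single step cannot say whether the same holds for a much longer chain, such as octyl or dodecyl, or for a branched chain such as isobutyl. It also leaves open whether an amine or a carboxylic acid at the end of the butyl chain would move the number beyond the scatter, and whether the same change would behave alike on a shorter chain, as in methyl to ethyl.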